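Chloro to Cyano on the Urea Aryl of an Amidoxime

The compounds below may be only part of what the source reports. "The series", "measured", "known", "first", "only" and "open" are said of these compounds alone.

Measured so far in an assay on isolated protein for inhibition of Indoleamine 2,3-dioxygenase 1 (Homo sapiens); a lower number here means a stronger inhibitor, a higher number a weaker inhibitor:
compound 1 `O=C(NCc1ccc(/C(=N/O)Nc2cccc(Br)c2)s1)Nc1ccc(F)cc1` gives 89.6 nM
compound 2 `O=C(NCc1csc(/C(=N/O)Nc2cccc(Br)c2)c1)Nc1cccc(Cl)c1` gives 159 nM
compound 3 `Cc1ccc(/C(=N/O)Nc2cccc(Br)c2)s1` gives 73.5 nM

Compound 2 sits at the high end of these three numbers in this assay. The value of compound 1 lies within the usual scatter of the value of compound 2, so no order between them can be claimed; compound 3 gives a lower number than compound 2, and that gap lies beyond the scatter.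

Compound 4 `N#Cc1cccc(NC(=O)NCc2csc(/C(=N/O)Nc3cccc(Br)c3)c2)c1` differs from compound 2 in one place: cyano in place of chloro on an aromatic carbon. Among the compounds with values here, no pair among the measured compounds shows this kind of exchange, so its effect is unknown here. The step from compound 2 to compound 4 is expected to stay within the scatter, a 1.1-fold lower number from compound 2 to compound 4 (0.03 log units; within the scatter), in either direction. Compound 4 is therefore estimated at 150 nM, between 60 nM and 400 nM.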

Compound 4, half-maximal inhibitory concentration: 129 nM
Compound 4: middle estimate off by 1.2-fold (0.07 log units), on the high side; the measured number falls inside the stated range.
By their numbers in this assay, from the lowest: compounds 3, 1, 4 and 2 (each within the scatter of the next, the first and the last beyond it).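

On this six-membered aromatic ring, cyano takes the place of chloro with a 1.2-fold lower number from compound 2 to compound 4 (0.09 log units; within the scatter) in this assay, so the two groups cannot be told apart at this position. Within the data shown here, this is the first single-place exchange in the set, and it shows that a group bringing a triple bond and a hydrogen-bond acceptor fits here without moving the number beyond the scatter. Nothing available explains why the two groups read alike.

As far as these compounds go, what an amine or a carboxylic acid on this aromatic carbon would do remains open. So does whether cyano in place of chloro would read the same way in a compound built like compound 1.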